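A few compounds are considered here, and "the series" means these few. Any claim that something is new, unique, unknown or untested is made for them only; others in the source may bear on it.

Compound 1 `NS(=O)(=O)c1cccc(-c2ccc3nccc(-c4ccncc4)c3n2)c1`: < 5000 nM
Compound 2 `NS(=O)(=O)c1cccc(-c2ccc3nccc(-c4ccncc4F)c3n2)c1`: < 5000 nM

In a physicochemical assay for solubility, read by HPLC, using the shake flask method, measured as kinetic solubility, with a stated time of 20 h, at pH 6.5, tested at 200 uM (on this read-out lower numbers stand for lower solubility and higher numbers for higher solubility), compound 1 gives < 5000 nM, which is a limit of the assay and not a number. Compound 2 gives < 5000 nM, which is also a limit. Compound 1 therefore stands only on (the limit of < 5000 nM in this assay, at which 2 of the 2 values shown sit).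

Compound 3 `Nc1cccc(-c2ccc3nccc(-c4ccncc4)c3n2)c1` departs from compound 1 by amino in place of sulfamoyl on an aromatic carbon. Within the data shown here, the only measured step is a step that the two limits leave unreadable from compound 1 to compound 2. It is a different change, fluoro in place of hydrogen, and it offers no size to carry over. No step beyond the scatter is therefore expected in this assay, in either direction. The estimated step is a number no lower from compound 1 to compound 3 (the limit leaves the size open). For compound 3 the expected value is 5000 nM, with an estimated range from 2500 nM to 30000 nM.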

Compound 3, solubility: < 5000 nM
Compound 3 gave a limit, no number (the forecaster's own chance of this, stated with the estimate: 55%); the middle value sits exactly at the limit.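

No step can be read from compound 1 to compound 3 in this assay, because each gives only a limit and not a number: the limit of < 5000 nM in this assay, at which 3 of the 3 values shown sit.

The compounds shown leave open the actual solubility of all three, and whether amino in place of sulfamoyl shifts it in either direction.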